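Trimming the carbamate: from compound 2 toward compound 3

This account rests on a few compounds, and the source may have more. Where it says the series, first, only, none or still open, it means among the compounds named here.

Compound 1 `O=C(CN1CCNCC1)N1CCC(NS(=O)(=O)c2cc(S(=O)(=O)c3ccccc3)ccc2C(F)(F)F)CC1` and compound 2 `CC(C)(C)OC(=O)N1CCC[C@H]1C(=O)N1CCC(NS(=O)(=O)c2cc(S(=O)(=O)c3ccccc3)ccc2C(F)(F)F)CC1` share a core and differ at one carbonyl carbon. In a physicochemical assay for solubility (a lower number here means a less soluble compound, a higher number a more soluble compound), compound 1 gives 50000 nM, while compound 2 gives 25000 nM, and the step of a 2.0-fold lower number from compound 1 to compound 2 (0.30 log units; within the scatter) stays within the scatter. Among the measured compounds shown here, compound 2 holds the lower of the two numbers, with compound 1 as its only neighbour. Compound 3 `CC(=O)N1CCC[C@H]1C(=O)N1CCC(NS(=O)(=O)c2cc(S(=O)(=O)c3ccccc3)ccc2C(F)(F)F)CC1` now follows from compound 2 by methyl in place of tert-butoxy on a carbonyl carbon. For the measured compounds named here, no measured step concerns this kind of change, and the single measured step was itself within the scatter. Compound 3 is therefore expected near the measured numbers, as a 2.0-fold higher number from compound 2 to compound 3 (0.30 log units; within the scatter), giving an estimate of 50000 nM with a range from 15000 nM to 150000 nM.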

Compound 3, solubility: 12500 nM
Beside the measured number, compound 3's estimate is 4.0-fold (0.60 log units) above it; measured number outside the range, below it.
By their numbers in this assay, from the lowest: compounds 3, 2 and 1 (each within the scatter of the next, the first and the last beyond it).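

Methyl in place of tert-butoxy on this carbonyl carbon gives a 2.0-fold lower number from compound 2 to compound 3 (0.30 log units; within the scatter) in this assay and so cannot be told apart from repeat scatter on its own. Among the compounds shown here, the wider change, 1-acetylpyrrolidin-2-yl in place of (piperazin-1-yl)methyl on a carbonyl carbon, gives a 4.0-fold lower number from compound 1 to compound 3 (0.60 log units; beyond the scatter) and is the first step here to pass the scatter. Nothing measured here accounts for either step.

As far as these compounds go, it remains open how an amine or a carboxylic acid in place of methyl on this carbonyl carbon would read in this assay and whether a longer chain there would stay within the scatter of compound 3.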